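Compound 3 to compound 4: a swap on the ring nitrogen

The source may hold more compounds than are shown below. What is called first, only, known or untested is meant among the compounds shown, and "the series" means these compounds.

Measured in an ADME assay on microsomes from liver (Homo sapiens) for metabolic stability, read by LC-MS, using NADPH, with a stated time of 10 min, tested at 0.1 uM; a higher number here means faster removal of the compound, a lower number slower removal:
Compound 1 `Cc1cccc(N2C(=O)CSC2c2cccc(C(=O)NCCCCc3ccccc3)c2)c1` gives 2550 mL.min-1.g-1
Compound 2 `O=C(NCCCCn1cccn1)c1cccc(C2SCC(=O)N2c2ccccn2)c1` gives 82.1 mL.min-1.g-1
Compound 3 `O=C(NCCCCc1ccccc1)c1cccc(C2SCC(=O)N2c2cccc(-c3c[nH]nn3)c2)c1` gives 261 mL.min-1.g-1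

Compound 3 stands second highest of these three numbers, below compound 1 and above compound 2. Compound 4 `O=C(NCCCCc1ccccc1)c1cccc(C2SCC(=O)N2c2ccccn2)c1` differs from it on an amide-type nitrogen in a ring, where pyridin-2-yl enters (a group of 6 heavy atoms (5 carbon, 1 nitrogen; one six-membered aromatic ring with 1 hetero atom) in place of a group of 11 heavy atoms (8 carbon, 3 nitrogen; one five-membered aromatic ring with 3 hetero atoms, one six-membered aromatic ring of carbon only), on an amide-type nitrogen in a ring). Among the compounds with values here, the one measured step at this place is a 9.8-fold lower number from compound 1 to compound 3 (0.99 log units; beyond the scatter) and it brought the triazolyl group in, which now leaves. Within the data shown here, compound 2 also carries pyridin-2-yl and gives 82.1 mL.min-1.g-1 but differs elsewhere too, so it offers no clean step and only widens the range. A partial move back upward in this assay is expected, and the estimated step is a 2.7-fold higher number from compound 3 to compound 4 (0.43 log units; beyond the scatter) in size. Compound 4 is expected to give 700 mL.min-1.g-1 with 230 mL.min-1.g-1 to 2100 mL.min-1.g-1 as its estimated range.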

Compound 4, intrinsic clearance in microsomes: 412 mL.min-1.g-1
Compound 4: the middle estimate sits 1.7-fold (0.23 log units) above what was measured; measured number inside the range.
By their numbers in this assay, from the lowest: compound 2; then compounds 3 and 4 (each within the scatter of the next); then compound 1.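

In this assay, pyridin-2-yl in place of 3-methylphenyl on the ring nitrogen gives a 6.2-fold lower number from compound 1 to compound 4 (0.79 log units; beyond the scatter) and the swap from compound 3 gives a 1.6-fold higher number from compound 3 to compound 4 (0.20 log units; within the scatter) so the fall from compound 1 is not tied to the triazolyl group. The far end of the chain also counts: phenyl in place of 1H-pyrazol-1-yl gives a 5.0-fold higher number from compound 2 to compound 4 (0.70 log units; beyond the scatter) with pyridin-2-yl held constant. No measured evidence explains these steps. On these data alone, what a carboxylic acid or an amine at the chain end would give stays open, as does whether that chain-end step holds with other groups on the ring nitrogen.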